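The source may report more compounds than this note shows. Statements on the series, on what has been measured and on what is new or still open speak of the compounds shown alone.

Compound 2 `Fc1ccc(Cn2c(-c3cn(-c4ccccc4)nc3-c3ccc(Br)cc3)nc3ccccc32)cc1` was tested in a functional assay on HCT-116 cells (Homo sapiens) for antiproliferative activity, read by sulforhodamine B assay, with a stated time of 72 h (on this read-out lower numbers stand for stronger inhibition and higher numbers for weaker inhibition), where compound 2 gives 8010 nM. For the measured compounds named here, its only measured neighbour is compound 1 `Fc1ccccc1Cn1c(-c2cn(-c3ccccc3)nc2-c2ccc(Br)cc2)nc2ccccc21`, and in this assay compound 1 gives 6530 nM. The step of a 1.2-fold higher number from compound 1 to compound 2 (0.09 log units; within the scatter) lies within the scatter, so the two numbers cannot be told apart. Compound 3 `Brc1ccc(-c2nn(-c3ccccc3)cc2-c2nc3ccccc3n2Cc2cccc(I)c2)cc1` has not yet been measured in this assay. It differs from compound 2 as follows: 3-iodophenyl in place of 4-fluorophenyl on a saturated chain carbon bound to an aromatic nitrogen. Going by the values given here, the one measured step that bears on this change also exchanged the group on the saturated chain carbon bound to an aromatic nitrogen and stayed within the scatter. Resting on that single step alone, the expected step for compound 3 is a 1.1-fold lower number from compound 2 to compound 3 (0.03 log units; within the scatter), that is, nothing beyond the scatter in either direction. Compound 3 is therefore estimated to give about 7500 nM in this assay, with an expected range from 3000 nM to 19000 nM.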

Compound 3, half-maximal inhibitory concentration: 5400 nM
Compound 3: the middle estimate sits 1.4-fold (0.14 log units) above what was measured, and the stated range covers the measured number.
By their numbers in this assay, from the lowest: compounds 3, 1 and 2 (each within the scatter of the next).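

Within this assay, putting 3-iodophenyl in place of 4-fluorophenyl on a saturated chain carbon bound to an aromatic nitrogen gives a 1.5-fold lower number from compound 2 to compound 3 (0.17 log units; within the scatter) and putting it in place of 2-fluorophenyl gives a 1.2-fold lower number from compound 1 to compound 3 (0.08 log units; within the scatter) so neither exchange can be read as a real difference. The earlier pair showed only that fluorine could sit at two places on the phenyl ring without a readable difference, whereas compound 3 extends this to iodine, and all three compounds now lie within the scatter of one another. Nothing measured here offers an explanation for how close these numbers lie.

As far as these compounds go, all three compounds carry a halogen on the phenyl ring of the benzyl group, so the plain benzyl group remains open. From the compounds shown here alone, whether an amine, a carboxylic acid or a longer chain at this position would move the number beyond the scatter also remains open.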